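Replacing Trifluoromethyl With a Carboxypyridine on the Oxazole

This account rests on a few compounds, and the source may have more. Where it says the series, first, only, none or still open, it means among the compounds named here.

Within the data shown here, in an assay (Rattus norvegicus) for inhibition of Fatty-acid amide hydrolase 1 (Homo sapiens) (on this read-out lower numbers stand for stronger inhibition and higher numbers for weaker inhibition), compound 2 `OC(CCCCCCc1ccccc1)c1ncc(C(F)(F)F)o1` gives 2300 nM, the highest of the two numbers known, while compound 1 `O=C(CCCCCCc1ccccc1)c1ncc(-c2ccccc2F)o1` gives 110 nM, a gap beyond the usual scatter. Compound 3 `O=C(O)c1ccc(-c2cnc(C(O)CCCCCCc3ccccc3)o2)nc1` differs from compound 2 in one place: 5-carboxypyridin-2-yl in place of trifluoromethyl on an aromatic carbon. Among the measured compounds shown here, no measured pair shows what such a change does here, so the direction rests on compound 1 alone, whose aryl substituent at the same place goes with a lower number. A moderate downward step is expected, a 3.8-fold lower number from compound 2 to compound 3 (0.58 log units; beyond the scatter). In this assay compound 3 is estimated at 600 nM, between 100 nM and 4000 nM.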

Compound 3, inhibition constant: 45000 nM
Compound 3: the middle estimate sits 75-fold (1.88 log units) below what was measured, outside the stated range (above it).
By their numbers in this assay, from the lowest: compound 1; then compound 2; then compound 3.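

In this assay, putting 5-carboxypyridin-2-yl in place of trifluoromethyl on the aromatic carbon next to the ring oxygen gives a 20-fold higher number from compound 2 to compound 3 (1.29 log units; beyond the scatter). This position is therefore sensitive to what it carries, and this particular aromatic ring with its carboxylic acid weakens inhibition strongly. Nothing available explains the loss.

Still open, going by these compounds, is whether the loss follows the carboxylic acid or the pyridine ring, which a methyl ester or an unsubstituted pyridin-2-yl at this place could separate. Also open, on these data alone, is whether the same exchange acts alike when a ketone replaces the alcohol.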